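The source may report more compounds than this note shows. Statements on the series, on what has been measured and on what is new or still open speak of the compounds shown alone.

Working notes on the series. Compound 2 `C#CCSc1cnc2ccccc2c1SCC#CCOC(=O)/C=C/c1ccccc1` and compound 1 `CSc1cnc2ccccc2c1SCC#CCOC(=O)/C=C/c1ccccc1` share a core and differ by hydrogen in place of ethynyl on a saturated chain carbon bound to a sulfur; in a functional assay on B16 cells (Mus musculus) for antiproliferative activity, with a stated time of 72 h (on this read-out lower numbers stand for stronger inhibition and higher numbers for weaker inhibition), compound 2 gives 14.7 ug/mL and compound 1 gives 9.4 ug/mL, so the step of a 1.6-fold lower number from compound 2 to compound 1 (0.19 log units; within the scatter). Compound 3 `C#CCSc1cnc2ccccc2c1SCC#CCCl` carries a different side chain; the difference between its core and that of compound 2 is not broken down here. In this assay compound 3 gives 52.8 ug/mL, the highest of the three numbers. Compound 4 `CSc1cnc2ccccc2c1SCC#CCCl` differs from compound 3 by hydrogen in place of ethynyl on a saturated chain carbon bound to a sulfur, the same change as from compound 2 to compound 1. Because the step of a 1.6-fold lower number from compound 2 to compound 1 (0.19 log units; within the scatter) was small, the expected step of a 1.4-fold lower number from compound 3 to compound 4 (0.14 log units; within the scatter) is also small. For compound 4 in this assay the estimate is 38 ug/mL, between 20 ug/mL and 75 ug/mL.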

Compound 4, concentration for 50% inhibition: 16.9 ug/mL
Beside the measured number, compound 4's estimate is 2.2-fold (0.35 log units) above it, and the stated range ends above it.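

In this assay, the change of propargyl to methyl gives a 3.1-fold lower number from compound 3 to compound 4 (0.49 log units; beyond the scatter). Set beside the earlier step, the two cannot be told apart on these numbers: the same change on two cores in this assay, a 1.6-fold lower number (0.19 log units; within the scatter) from compound 2 to compound 1 and a 3.1-fold lower number (0.49 log units; beyond the scatter) from compound 3 to compound 4, 2.0-fold (0.30 log units) apart, within the scatter of two such steps

This fits the change carrying from one core to the other in this series, but it rests on two pairs in one assay and does not show that the step keeps a fixed size on other cores, nor why it has the size it has.

The compounds shown leave open what an ethyl or a longer chain would do in place of the methyl. They also leave open whether the step holds with an amine or a carboxylic acid in place of the chlorine.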